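From fluoro to bromo on a shared core

This account rests on a few compounds, and the source may have more. Where it says the series, first, only, none or still open, it means among the compounds named here.

- Compound 1 `Fc1ccc(-c2nn(-c3ccccc3)cc2-c2nc3cc(Br)ccc3[nH]2)cc1`: 4940 nM
- Compound 2 `Fc1ccc2[nH]c(-c3cn(-c4ccccc4)nc3-c3ccc(Cl)cc3)nc2c1`: 2770 nM

Both compounds were tested in a functional assay on HeLa cells (Homo sapiens) for antiproliferative activity, read by MTT assay, with a stated time of 48 h; a higher number here means a weaker inhibitor, a lower number a stronger inhibitor. Compound 2 gives 2770 nM and compound 1 gives 4940 nM, and these two values lie within the usual scatter of each other. Among the compounds with values here, compound 2 therefore stands level with the only other measured compound.

The next compound to be measured is compound 3 `Clc1ccc(-c2nn(-c3ccccc3)cc2-c2nc3cc(Br)ccc3[nH]2)cc1`. It carries bromo in place of fluoro on an aromatic carbon of compound 2, on a six-membered aromatic ring of carbon only that is part of a fused system of two rings (bromo in place of fluoro on an aromatic carbon). Within the data shown here, no measured pair shows this change in a single place, so the data give no direct gauge of its size. With compound 1 at 4940 nM and compound 2 at 2770 nM, no change beyond the scatter is expected in this assay. The expected step, a 1.3-fold higher number from compound 2 to compound 3 (0.10 log units; within the scatter), is estimated to stay within the scatter. For compound 3 the estimated value is 3500 nM, with an expected range of 1500 nM to 8000 nM.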

Compound 3, half-maximal inhibitory concentration: 2160 nM
Estimate against measurement, compound 3: 1.6-fold (0.21 log units) above, within the range that was stated.
By their numbers in this assay, from the lowest: compounds 3, 2 and 1 (each within the scatter of the next, the first and the last beyond it).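

In this assay, bromo in place of fluoro on an aromatic carbon of the fused system of two rings gives a 1.3-fold lower number from compound 2 to compound 3 (0.11 log units; within the scatter) and so leaves the number level: at this position, the data do not separate these two halogens. Going from fluoro to chloro, a change in a different place on the shared core, gives a 2.3-fold lower number from compound 1 to compound 3 (0.36 log units; beyond the scatter) and is the first step here to pass beyond the scatter, though only modestly. Nothing available accounts for either step.

From the compounds shown here alone, whether a group other than a halogen, such as an amine or a carboxylic acid, would move the number beyond the scatter at the position of the bromo remains open. Going by these compounds, it also remains open whether either step would hold in cells other than HeLa.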